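A few compounds are considered here, and "the series" means these few. Any claim that something is new, unique, unknown or untested is made for them only; others in the source may bear on it.

Three thiosemicarbazones sharing one core are compared in a functional assay on MCF7 cells (Homo sapiens) for cytotoxicity, read by MTT assay, with a stated time of 48 h; a lower number here means a stronger inhibitor, a higher number a weaker inhibitor. Compound 1 `CC(=NNC(=S)Nc1ccccc1F)c1ccccn1` gives 0.39 nM, the lowest of the three numbers. Compound 3 `CC(=NNC(=S)Nc1cccc(F)c1)c1ccccn1` gives 9 nM; compound 3 and compound 1 contain the same atoms joined differently, and the difference between the two cores is not broken down here. Compound 2 `CC(=NNC(=S)Nc1cccc([N+](=O)[O-])c1)c1ccccn1` gives 38 nM. Compound 2 differs from compound 3 by nitro in place of fluoro on an aromatic carbon, a change recorded as a 4.2-fold higher number from compound 3 to compound 2 (0.63 log units; beyond the scatter). Compound 4 `CC(=NNC(=S)Nc1ccccc1[N+](=O)[O-])c1ccccn1` is not yet measured; it differs from compound 1 by nitro in place of fluoro on an aromatic carbon, the same kind of change, but here the place is ortho to a large group rather than meta to a large group. Among the compounds with values here, the step expected from compound 1 to compound 4 is a 4.6-fold higher number from compound 1 to compound 4 (0.66 log units; beyond the scatter), resting on the one measured instance a 4.2-fold higher number from compound 3 to compound 2 (0.63 log units; beyond the scatter); the place differs, so the range is kept wide. Compound 4 is expected near 1.8 nM, between 0.5 nM and 8 nM.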

Compound 4, half-maximal inhibitory concentration: 5.7 nM
Compound 4: the middle estimate sits 3.2-fold (0.50 log units) below what was measured; low and high end bracket the measured number.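

In this assay, nitro in place of fluoro gives a higher number on both cores, with a 15-fold higher number from compound 1 to compound 4 (1.16 log units; beyond the scatter) as the newer and larger step, so in these two pairs the direction carries over but the size does not: the same change on two cores in this assay, a 4.2-fold higher number (0.63 log units; beyond the scatter) from compound 3 to compound 2 and a 15-fold higher number (1.16 log units; beyond the scatter) from compound 1 to compound 4, 3.5-fold (0.54 log units) apart, beyond the scatter of two such steps A step measured on one core is therefore a poor guide to the size of the same change on the other. Two pairs do not show what sets the size of the step, nor whether the direction would hold on a further core.

The compounds shown leave open how an amine or a carboxylic acid on the same aromatic carbon would compare with fluoro and nitro. Also open, as far as these compounds go, is whether either step would keep its size with a longer chain in place of the methyl group.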